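A Chloro Group Enters the Propanoyl Chain

The source may hold more compounds than are shown below. What is called first, only, known or untested is meant among the compounds shown, and "the series" means these compounds.

Three measured compounds share one core and differ only in the group on the carbonyl carbon of the amide. Compound 1 `COc1ccc(CN(C(=O)C(C)Br)c2cc(OC)c(OC)c(OC)c2)cc1O` carries 1-bromoethyl there, and in a functional assay on MGC-803 cells (Homo sapiens) for inhibition, read by MTT assay, with a stated time of 48 h (on this read-out lower numbers stand for stronger inhibition and higher numbers for weaker inhibition), compound 1 gives 120 nM. Compound 2 `CC/C=C/C(=O)N(Cc1ccc(OC)c(O)c1)c1cc(OC)c(OC)c(OC)c1` carries but-1-en-1-yl and gives 58 nM. Compound 3 `CCC(=O)N(Cc1ccc(OC)c(O)c1)c1cc(OC)c(OC)c(OC)c1` carries ethyl and gives 50 nM, the lowest of the three numbers; its gap to compound 2 lies within the scatter, while a 2.4-fold lower number from compound 1 to compound 3 (0.38 log units; beyond the scatter) and a 2.1-fold lower number from compound 1 to compound 2 (0.32 log units; beyond the scatter) lie beyond it.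

Compound 4 `COc1ccc(CN(C(=O)CCCl)c2cc(OC)c(OC)c(OC)c2)cc1O` differs from compound 3 by chloro in place of hydrogen on a saturated chain carbon, two bonds along the chain from a carbonyl carbon. The nearest guide is a 2.4-fold lower number from compound 1 to compound 3 (0.38 log units; beyond the scatter), where a bromo group left a saturated chain carbon bound to the carbonyl carbon and the number fell. Here a chloro group enters on a saturated chain carbon two bonds along the chain from the carbonyl carbon, so a move back toward a higher number is expected, though possibly not beyond the scatter. The expected step is a 1.6-fold higher number from compound 3 to compound 4 (0.20 log units; within the scatter). In this assay compound 4 is expected to give 80 nM, within a range from 35 nM to 200 nM.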

Compound 4, half-maximal inhibitory concentration: 140 nM
Compound 4: the middle estimate sits 1.8-fold (0.24 log units) below what was measured, within the range that was stated.
By their numbers in this assay, from the lowest: compounds 3 and 2 (each within the scatter of the next); then compounds 1 and 4 (each within the scatter of the next).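

In this assay, among the compounds shown here, the halogen effect now reaches further along the chain: until now a halogen had been seen only on the chain carbon bound to the carbonyl carbon, and a 2.8-fold higher number from compound 3 to compound 4 (0.45 log units; beyond the scatter) shows that a single chloro group two bonds along the chain from the carbonyl carbon also moves the number beyond the scatter. The placement of the halogen and the type of halogen differ between the two chains, yet a 1.2-fold higher number from compound 1 to compound 4 (0.07 log units; within the scatter) stays within the scatter, while a 2.4-fold higher number from compound 2 to compound 4 (0.38 log units; beyond the scatter) separates the 2-chloroethyl group from the but-1-en-1-yl group, so both halogen-bearing compounds stand above compounds 2 and 3. No measurement shown here explains why chloro raises the number at this position.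

Still open, as far as these compounds go, is whether a bromo, a hydroxyl or an amine on the same chain carbon would give a similar number. From the compounds shown here alone, it is also open whether a longer chain ending in chloro would follow compound 4.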